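The source may report more compounds than this note shows. Statements on the series, on what has been measured and on what is new or still open speak of the compounds shown alone.

Measured so far in a functional assay on MKN-45 cells (Homo sapiens) for cytotoxicity, read by MTT assay, with a stated time of 72 h; on this read-out lower numbers stand for stronger inhibition and higher numbers for weaker inhibition:
- compound 1, `CN(C)CCn1cnnc1-c1cc(Oc2ccc(NC(=O)N/N=C/c3cc(Br)c(O)c(Br)c3)cc2F)ccn1`: 4320 nM
- compound 2, `CN(C)CCn1cnnc1-c1cc(Oc2ccc(NC(=O)N/N=C/c3ccc(O)c(F)c3)cc2F)ccn1`: 1970 nM
- compound 3, `CN(C)CCn1cnnc1-c1cc(Oc2ccc(NC(=O)N/N=C/c3ccc(F)cc3Cl)cc2F)ccn1`: 870 nM

Compound 3 gives the lowest number of the three: the step of a 2.3-fold lower number from compound 2 to compound 3 (0.35 log units; beyond the scatter) and the step of a 5.0-fold lower number from compound 1 to compound 3 (0.70 log units; beyond the scatter) both lie beyond the scatter, so within this set compound 3 is the most potent. The step of a 2.2-fold lower number from compound 1 to compound 2 (0.34 log units; beyond the scatter) is of similar size.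

Compound 4, `CN(C)CCn1cnnc1-c1cc(Oc2ccc(NC(=O)N/N=C/c3ccc(O)cc3O)cc2F)ccn1`, differs from compound 3 in one place: 2,4-dihydroxyphenyl in place of 2-chloro-4-fluorophenyl on a carbon with a double bond to nitrogen. Within the data shown here, no measured pair shows exactly this swap. Among the measured compounds shown here, the steps that bear on it run the other way: both compounds carrying a hydroxyl on this ring, compound 1 and compound 2, sit above compound 3, by a 5.0-fold lower number from compound 1 to compound 3 (0.70 log units; beyond the scatter) and a 2.3-fold lower number from compound 2 to compound 3 (0.35 log units; beyond the scatter). From the compounds shown here alone, exchanging the two halogens of compound 3 for two hydroxyls is therefore expected to raise the number in this assay by a modest amount, roughly the size of those steps, though the direction of a second hydroxyl is untested here.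

Compound 4 is estimated at 2500 nM in this assay, with a range of 900 nM to 7000 nM, which means an expected step of a 2.9-fold higher number from compound 3 to compound 4 (0.46 log units; beyond the scatter).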

Compound 4, half-maximal inhibitory concentration: 2860 nM
Beside the measured number, compound 4's estimate is 1.1-fold (0.06 log units) below it; the measured number falls inside the stated range.
By their numbers in this assay, from the lowest: compound 3; then compounds 2, 4 and 1 (each within the scatter of the next, the first and the last beyond it).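

In this assay, the 2,4-dihydroxyphenyl group of compound 4 separates from the 2-chloro-4-fluorophenyl group (a 3.3-fold higher number from compound 3 to compound 4 (0.52 log units; beyond the scatter)) but not from the other two hydroxyl-bearing rings (a 1.5-fold higher number from compound 2 to compound 4 (0.16 log units; within the scatter); a 1.5-fold lower number from compound 1 to compound 4 (0.18 log units; within the scatter)). A ring with hydroxyls and no halogen thus reads like those carrying a hydroxyl with fluorine or bromine, so at this position halogen on a hydroxyl-bearing ring is not needed to stay in that range, and all three hydroxyl-bearing compounds sit above compound 3, with none going against this. No measurement at hand accounts for the gap.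

The compounds shown leave open whether the higher numbers follow from gaining hydroxyl or from losing chlorine and fluorine. A plain phenyl, a methoxyphenyl or an aminophenyl at this position would help separate the two readings.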